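This account rests on a few compounds, and the source may have more. Where it says the series, first, only, none or still open, it means among the compounds named here.

Measured compounds in a functional assay, with a stated time of 6 min; on this read-out higher numbers stand for weaker inhibition and lower numbers for stronger inhibition:
compound 1, `COc1ccc(NCn2nc(-c3ccc4c(c3)OCCO4)oc2=S)cc1`: 5830 nM
compound 2, `Fc1cccc(F)c1NCn1nc(-c2ccc3c(c2)OCCO3)oc1=S`: 3320 nM
compound 3, `S=c1oc(-c2ccc3c(c2)OCCO3)nn1CNc1cccc(Cl)c1`: 6220 nM

Compound 1 sits second highest of the three numbers in this assay; its neighbours are compound 3 with a 1.1-fold higher number from compound 1 to compound 3 (0.03 log units; within the scatter) and compound 2 with a 1.8-fold lower number from compound 1 to compound 2 (0.24 log units; within the scatter), both within the scatter. The remaining pair, a 1.9-fold higher number from compound 2 to compound 3 (0.27 log units; within the scatter), is also within the scatter, so swapping the aryl group on the amine nitrogen has so far not moved the read-out beyond noise.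

Compound 4, `S=c1oc(-c2ccc3c(c2)OCCO3)nn1CNc1ccc(Br)cc1`, differs from compound 1 by bromo in place of methoxy on an aromatic carbon. This is again a change of the aryl group on the amine nitrogen, the kind of change that gave no step beyond the scatter in the three measured pairs. Compound 4 is therefore expected to give a number close to that of compound 1, with a 1.1-fold lower number from compound 1 to compound 4 (0.03 log units; within the scatter), and an estimate of 5500 nM within 2500 nM to 12000 nM.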

Compound 4, half-maximal inhibitory concentration: 14700 nM
The estimate for compound 4 lay 2.7-fold (0.43 log units) below the measured number, outside the stated range (above it).
By their numbers in this assay, from the lowest: compounds 2, 1 and 3 (each within the scatter of the next); then compound 4.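

In this assay, among the compounds shown here, the aryl group on the amine nitrogen is no longer without effect: 4-bromophenyl gives the first steps at this position beyond the scatter, all modest and all towards weaker inhibition (a 2.5-fold higher number from compound 1 to compound 4 (0.40 log units; beyond the scatter); a 2.4-fold higher number from compound 3 to compound 4 (0.37 log units; beyond the scatter); a 4.4-fold higher number from compound 2 to compound 4 (0.65 log units; beyond the scatter)). Bromo in place of methoxy on this aromatic carbon is therefore not a neutral swap, whereas compound 1, compound 2 and compound 3 stay within the scatter of one another. No measurement at hand bears on the reason for these steps.

Going by these compounds, it remains open whether the loss is particular to bromo or would also follow from a nitrile or a carboxylic acid on the same aromatic carbon. Any aryl change giving a number beyond the scatter on the lower side also remains to be seen.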